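Bromo to Hydrogen on the Phenoxy Ring in MCF7 Cytotoxicity

This account rests on a few compounds, and the source may have more. Where it says the series, first, only, none or still open, it means among the compounds named here.

Compound 2 `Cc1ccc(-c2csc(NC(=O)COc3ccc(Br)cc3)n2)cc1` carries a 4-bromophenoxy group and a 4-methylphenyl arm on the shared core. In a functional assay on MCF7 cells (Homo sapiens) for cytotoxicity, read by trypan blue exclusion, with a stated time of 48 h (on this read-out higher numbers stand for weaker inhibition and lower numbers for stronger inhibition), compound 2 gives 39000 nM. Compound 1 `Cc1ccc(-c2csc(NC(=O)COc3ccccc3)n2)cc1` differs from compound 2 by hydrogen in place of bromo on an aromatic carbon, and in this assay compound 1 gives 43000 nM; the step is a 1.1-fold higher number from compound 2 to compound 1 (0.04 log units; within the scatter). Compound 3 `O=C(COc1ccc(Br)cc1)Nc1nc(-c2ccc(Cl)cc2)cs1` differs from compound 2 by chloro in place of methyl on an aromatic carbon, and in this assay compound 3 gives 52100 nM, so a 1.3-fold higher number from compound 2 to compound 3 (0.13 log units; within the scatter). Compound 4 `O=C(COc1ccccc1)Nc1nc(-c2ccc(Cl)cc2)cs1` stands to compound 3 as compound 1 stands to compound 2: hydrogen in place of bromo on an aromatic carbon, the same change made on the core of compound 3. Because the earlier step of a 1.1-fold higher number from compound 2 to compound 1 (0.04 log units; within the scatter) stayed within the scatter, compound 4 is expected to sit close to compound 3. Compound 4 is therefore expected to move by a 1.1-fold higher number from compound 3 to compound 4 (0.04 log units; within the scatter). The estimate for compound 4 in this assay is 57000 nM, expected between 28000 nM and 115000 nM.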

Compound 4, half-maximal inhibitory concentration: 55900 nM
For compound 4 the middle estimate is 1.0-fold (0.01 log units) above the measured one; the measured number falls inside the stated range.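

Carried to a second core, the change from 4-bromophenoxy to phenoxy in this assay gives a 1.1-fold higher number from compound 3 to compound 4 (0.03 log units; within the scatter), and it reads the same on both cores: the same change on two cores in this assay, a 1.1-fold higher number (0.04 log units; within the scatter) from compound 2 to compound 1 and a 1.1-fold higher number (0.03 log units; within the scatter) from compound 3 to compound 4, 1.0-fold (0.01 log units) apart, within the scatter of two such steps
The swap of methyl for chloro carries over in the same way, with a 1.3-fold higher number from compound 1 to compound 4 (0.11 log units; within the scatter): the same change on two cores in this assay, a 1.3-fold higher number (0.13 log units; within the scatter) from compound 2 to compound 3 and a 1.3-fold higher number (0.11 log units; within the scatter) from compound 1 to compound 4, 1.0-fold (0.01 log units) apart, within the scatter of two such steps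
This shows that two steps within the scatter stay within it on a second core, but it does not show that a step beyond the scatter would carry across in this way.

From the compounds shown here alone, it remains open whether an amine or a carboxylic acid in place of the bromo would move the number on either core. Going by these compounds, whether a longer chain between the phenoxy group and the amide carbonyl would do so is also open.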